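Swapping a Pyridinyl for a Thiophenyl on a Shared Core

The source may hold more compounds than are shown below. What is called first, only, known or untested is meant among the compounds shown, and "the series" means these compounds.

Measured compounds:
compound 1 `Oc1ccc(-c2cc(-c3ccccn3)nc(-c3ccccc3Cl)c2)cc1`, "not determined" (no result reported) in an ADME assay on HEK293 cells (Homo sapiens) for cytotoxicity, read by CCK-8 assay and cell counting, with a stated time of 2 days; on this read-out lower numbers stand for stronger inhibition and higher numbers for weaker inhibition
compound 2 `Oc1ccc(-c2cc(-c3cccc(Cl)c3)nc(-c3ccccn3)c2)cc1`, 25400 nM
compound 3 `Oc1cccc(-c2cc(-c3ccc(Cl)cc3)nc(-c3cccs3)c2)c1`, 11800 nM

Compound 2 holds the highest of the two numbers shown; compound 3 sits at a lower number, and the two values differ by more than the scatter. Compound 1 carries no reading.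

Compound 4 `Oc1ccc(-c2cc(-c3cccc(Cl)c3)nc(-c3cccs3)c2)cc1` differs from compound 2 by thiophen-2-yl in place of pyridin-2-yl on an aromatic carbon. Among the measured compounds shown here, no step between measured compounds isolates this change, so compound 3, which also carries a thiophen-2-yl group but differs elsewhere as well, only hints at a direction. Compound 4 is expected to give a modestly lower number than compound 2, a step of a 1.7-fold lower number from compound 2 to compound 4 (0.23 log units; within the scatter), with an estimate of 15000 nM and a range from 6000 nM to 40000 nM.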

Compound 4, half-maximal inhibitory concentration: 2720 nM
Compound 4: the middle estimate sits 5.5-fold (0.74 log units) above what was measured; the whole stated range lies above it.
By their numbers in this assay, from the lowest: compound 4; then compound 3; then compound 2.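

In this assay, among the compounds shown here, thiophen-2-yl in place of pyridin-2-yl on this aromatic carbon, next to the ring nitrogen, gives a 9.3-fold lower number from compound 2 to compound 4 (0.97 log units; beyond the scatter) and is the first step in the set that isolates a single change. With the 3-chlorophenyl and 4-hydroxyphenyl groups held fixed, this one exchange moves the number beyond the scatter. Nothing measured here accounts for the size of the step. As far as these compounds go, it remains open how a furan-2-yl group or an amine at this position would read, and whether the step would persist with the 3-chlorophenyl group replaced.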